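Pyrrolidinyl amine replacing the propylamino chain on the methoxy core

The compounds below may be only part of what the source reports. "The series", "measured", "known", "first", "only" and "open" are said of these compounds alone.

Three compounds of the series carry numbers in an assay on isolated protein for inhibition of DNA topoisomerase 1 (Homo sapiens), with a stated time of 15 min; a lower number here means a stronger inhibitor, a higher number a weaker inhibitor. Compound 1 `CNC[C@@H]1CCN(c2cc3c(cc2F)c(=O)c(C(=O)O)cn3Cc2ccc(-n3cccn3)cc2)C1` gives > 200000 nM there, which is a limit of the assay rather than a number; it carries the same 3-((methylamino)methyl)pyrrolidin-1-yl group that enters below (the limit of > 200000 nM in this assay, at which 1 of the 3 values shown sits). Compound 2 `CNCCCNc1c(F)cc2c(=O)c(C(=O)O)cn(Cc3ccc(-c4ccccc4)cc3)c2c1OC` gives 101000 nM in this assay and compound 3 `NC[C@@H]1CCN(c2ccc3c(=O)c(C(=O)O)cn(Cc4ccc(-n5cccn5)cc4)c3c2)C1` gives 61000 nM; the two values sit within the scatter of each other, so no order between them can be read. Compound 2 thus stands among the weak end of the numbers shown, with no measured step to any neighbour.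

Compound 4 `CNC[C@@H]1CCN(c2c(F)cc3c(=O)c(C(=O)O)cn(Cc4ccc(-c5ccccc5)cc4)c3c2OC)C1` is the next analogue and differs from compound 2 as follows: 3-((methylamino)methyl)pyrrolidin-1-yl in place of (3-(methylamino)propyl)amino on an aromatic carbon. With no measured step of this kind in hand, and with compound 1 sitting at the limit, a step towards a weaker inhibitor, roughly beyond the scatter, is expected for compound 4, that is a 1.5-fold higher number from compound 2 to compound 4 (0.17 log units; within the scatter). Compound 4 is expected to give about 150000 nM in this assay, estimated between 50000 nM and 250000 nM, with a fair chance that only a limit is reported.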

Compound 4, half-maximal inhibitory concentration: 155000 nM
The estimate for compound 4 lay 1.0-fold (0.01 log units) below the measured number, within the range that was stated.
By their numbers in this assay, from the lowest: compounds 3, 2 and 4 (each within the scatter of the next, the first and the last beyond it). At a limit, above all of these: compound 1.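

In this assay, among the compounds shown here, this is the first measured step at this position, the aromatic carbon ortho to a fluoro group and ortho to a methoxy group: 3-((methylamino)methyl)pyrrolidin-1-yl in place of (3-(methylamino)propyl)amino gives a change within the scatter (a 1.5-fold higher number from compound 2 to compound 4 (0.19 log units; within the scatter)). On this core, closing the open chain into the five-membered ring therefore has no readable effect on the number, and this single pair gives no sign of a gain. Compound 1 remains the only limit in the series: the limit of > 200000 nM in this assay, at which 1 of the 4 values shown sits.

As far as these compounds go, whether the opposite configuration at the defined stereocentre would read differently stays open. So does the effect of a piperazine or a longer aminoalkyl chain on this aromatic carbon, and the pair does not show what holds these numbers at the weak end.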